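The source may hold more compounds than are shown below. What is called first, only, known or untested is meant among the compounds shown, and "the series" means these compounds.

In a functional assay on L1210 cells (Mus musculus) for inhibition; a lower number here means a stronger inhibitor, a higher number a weaker inhibitor:
- compound 1 `Nc1ncnc2c1ncn2C/C=C/CCl`: 45000 nM
- compound 2 `Nc1ncnc2c1ncn2C/C=C\CCl`: 22000 nM
- compound 3 `NC1=NC(N)c2c(ncn2C=C=CCO)N1`: 60000 nM

Compound 2 has the lowest of the three numbers, although all three values lie close together. The next compound is compound 4 `Nc1ncnc2c1ncn2C=C=CCCl`, which carries 4-chlorobuta-1,2-dien-1-yl in place of 4-chlorobut-2-en-1-yl on an aromatic nitrogen.

Within the data shown here, the only measured step within this chlorinated chain is a 2.0-fold lower number from compound 1 to compound 2 (0.31 log units; beyond the scatter), and it is modest. It reflects (the fact that compounds 1 and 2 differ only in the configuration as drawn), so it gives a size for a change in the chain's shape but no direct measure of the change to compound 4. With so little to go on, no large shift in this assay is expected, and no clear direction can be argued from one step. The expected move is a 1.4-fold higher number from compound 2 to compound 4 (0.13 log units; within the scatter), which is not expected to stand beyond the scatter. Compound 4 is estimated at 30000 nM, with an expected range of 10000 nM to 80000 nM.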

Compound 4, half-maximal inhibitory concentration: 45000 nM
For compound 4 the middle estimate is 1.5-fold (0.18 log units) below the measured one; the measured number falls inside the stated range.
By their numbers in this assay, from the lowest: compound 2; then compounds 1, 4 and 3 (each within the scatter of the next).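

In this assay, 4-chlorobuta-1,2-dien-1-yl in place of 4-chlorobut-2-en-1-yl on an aromatic nitrogen gives a 2.0-fold higher number from compound 2 to compound 4 (0.31 log units; beyond the scatter), and the same exchange gives no change at the digits printed from compound 1 to compound 4 (within the scatter). The second double bond outside aromatic rings therefore leaves the number level with the E-drawn chain of compound 1, and only the Z-drawn chain of compound 2 stands apart from compound 4. The separation of compound 2 from the other chlorinated chain thus rests on drawn geometry alone: the fact that compounds 1 and 2 differ only in the configuration as drawn.

The compounds shown do not tell which feature of the chain accounts for the step to compound 4. Going by these compounds, whether an amine or a longer chain in place of the chlorine would move the number out of this narrow band also remains open.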